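The source may report more compounds than this note shows. Statements on the series, on what has been measured and on what is new or still open speak of the compounds shown alone.

Working notes on the series. Compound 1, `O=c1c2ccccc2ccn1[C@@H]1O[C@H](COP(=O)(O)OP(=O)(O)OP(=O)(O)O)[C@@H](O)[C@H]1O`, carries hydrogen on the aromatic carbon in question. In a functional assay for agonist activity at P2Y purinoceptor 6 (Homo sapiens), read by FLIPR (a higher number here means that more compound is needed for the effect, a lower number that less compound is needed), compound 1 reaches only > 20000 nM, which is a limit of the assay and not a number. Compound 2, `O=c1c2cc(F)ccc2ccn1[C@@H]1O[C@H](COP(=O)(O)OP(=O)(O)OP(=O)(O)O)[C@@H](O)[C@H]1O`, carries fluoro on that aromatic carbon in place of hydrogen. In this assay compound 2 likewise reaches only > 20000 nM, again a limit and not a number. For the measured compounds named here, the step that the two limits leave unreadable from compound 1 to compound 2 is thus of unreadable size; the sole evidence on it is the limit of > 20000 nM in this assay, at which 2 of the 2 values shown sit. Compound 2 stands, on the numbers shown, at the same limit as compound 1, with no ranking between the two possible.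

Compound 3, `O=c1c2cc(Cl)ccc2ccn1[C@@H]1O[C@H](COP(=O)(O)OP(=O)(O)OP(=O)(O)O)[C@@H](O)[C@H]1O`, is the next member. It differs from compound 2 by chloro in place of fluoro on an aromatic carbon. Going by the values given here, the only measured step that bears on this change is a step that the two limits leave unreadable from compound 1 to compound 2, which gives no readable size in either direction, so no step beyond the scatter is expected in this assay, and a further limit is the likeliest outcome. Compound 3 is estimated at 30000 nM, within 5000 nM to 200000 nM, an expected step that the limit leaves unreadable from compound 2 to compound 3.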

Compound 3, half-maximal effective concentration: > 20000 nM
Compound 3: only a limit was reported (the forecaster's own chance of this, stated with the estimate: 85%); the middle value is on the limit's open side.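

Compound 3 also gives only > 20000 nM in this assay, a limit and not a number. The steps linking compound 1, compound 2 and compound 3 therefore cannot be read, and the sole evidence is this: the limit of > 20000 nM in this assay, at which 3 of the 3 values shown sit.

The compounds shown leave open whether any change to the shared core gives a measurable value in this assay.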